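Trifluoromethyl step on a benzoyl-substituted core, second pairing

This account rests on a few compounds, and the source may have more. Where it says the series, first, only, none or still open, it means among the compounds named here.

Measured so far:
compound 1 `O=C(O)c1ccc2ccc(C(=O)c3ccccc3)c-2cc1`, 11%
compound 2 `O=C(O)c1ccc2ccc(C(=O)c3ccc(C(F)(F)F)cc3)c-2cc1`, -81.5%
compound 3 `COC(=O)Cc1ccc2ccc(C(=O)c3ccccc3)c-2cc1`, -37.7%

In an assay on cells for displacement of a labelled ligand from Orexin/Hypocretin receptor type 1 (Homo sapiens), read by scintillation counting, with stated times of 10 min and 90 min, tested at 10 uM (a lower number here means less inhibition, a higher number more inhibition at the concentration tested (going by the name of the read-out)), compound 1 gives 11%. Compound 2 differs from compound 1 by trifluoromethyl in place of hydrogen on an aromatic carbon, and the step is a number 92.5 percentage points lower from compound 1 to compound 2 (beyond the scatter). Compound 3 carries a different core: the difference is (methoxycarbonyl)methyl in place of carboxy on an aromatic carbon, and the step is a number 48.7 percentage points lower from compound 1 to compound 3 (beyond the scatter). In this assay compound 3 gives -37.7%, which stands between the values of compound 1 and compound 2.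

Compound 4 `COC(=O)Cc1ccc2ccc(C(=O)c3ccc(C(F)(F)F)cc3)c-2cc1` has not been measured. It differs from compound 3 by trifluoromethyl in place of hydrogen on an aromatic carbon, which is the same change as that from compound 1 to compound 2, at the same place. Going by the values given here, the step from compound 3 to compound 4 is expected to be of the same direction and of similar size, a number 57.3 percentage points lower from compound 3 to compound 4 (beyond the scatter), because the single measured instance of this change is a number 92.5 percentage points lower from compound 1 to compound 2 (beyond the scatter). That expectation rests on one pair only, and the core of compound 3 is not the core of compound 1, so the range is kept wide. For compound 4 in this assay the estimate is -95%, between -150% and -40%.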

Compound 4, a percentage reported as inhibition, at one concentration (the size of the read-out at that concentration, not a potency): -30.4%
Beside the measured number, compound 4's estimate is 64.6 percentage points below it, outside the stated range (above it).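

In this assay, the trifluoromethyl change does not carry over from the carboxy compounds to the (methoxycarbonyl)methyl compounds, where it gives a number 7.3 percentage points higher from compound 3 to compound 4 (within the scatter), and the two steps differ: the same change on two cores in this assay, a number 92.5 percentage points lower (beyond the scatter) from compound 1 to compound 2 and a number 7.3 percentage points higher (within the scatter) from compound 3 to compound 4, 99.8 percentage points apart, beyond the scatter of two such steps

The swap of carboxy for (methoxycarbonyl)methyl likewise depends on the group at the other end of the molecule, giving a number 51.1 percentage points higher from compound 2 to compound 4 (beyond the scatter) with trifluoromethyl present, opposite in direction to the step without it: the same change on two cores in this assay, a number 48.7 percentage points lower (beyond the scatter) from compound 1 to compound 3 and a number 51.1 percentage points higher (beyond the scatter) from compound 2 to compound 4, 99.8 percentage points apart, beyond the scatter of two such steps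

In these four compounds the two changes therefore do not add, so a step measured on one core gives no guide to the other, but this rests on a single pair per core, does not show why the steps differ, and says nothing about other substituents or cores.

Going by these compounds, it remains open whether a nitrile or a chlorine at the same place would follow the pattern of trifluoromethyl on each core. A carboxymethyl group would help separate the effect of the longer chain from that of the methyl ester within the (methoxycarbonyl)methyl swap.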